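The compounds below may be only part of what the source reports. "The series", "measured", "known", "first", "only" and "open" are said of these compounds alone.

Series notes. Compound 1 `N#Cc1cc2cc(-c3ccccc3)n(O)c2cc1C#N`, compound 2 `Cc1ccc(-c2cc3cc(C#N)c(C#N)cc3n2O)cc1` and compound 3 `COn1c(-c2ccccc2)c(C=O)c2cc(C#N)c(C#N)cc21` have been tested in an assay on isolated protein for inhibition of Amine oxidase [flavin-containing] A (Homo sapiens), read by fluorescence and spectrophotometry, with a stated time of 20 min; on this read-out lower numbers stand for stronger inhibition and higher numbers for weaker inhibition. Compound 1 gives 6920 nM, compound 2 gives 1140 nM and compound 3 gives 522 nM, the lowest number of the three. Compound 1 and compound 2 differ in one place, (methyl in place of hydrogen on an aromatic carbon), and that change gave a 6.1-fold lower number from compound 1 to compound 2 (0.78 log units; beyond the scatter). How the core of compound 1 and the core of compound 3 differ is not broken down here. Compound 4 `COn1c(-c2ccc(C)cc2)c(C=O)c2cc(C#N)c(C#N)cc21` carries the same change on the core of compound 3, (methyl in place of hydrogen on an aromatic carbon). For compound 4 the expected step in this assay is a 2.9-fold lower number from compound 3 to compound 4 (0.46 log units; beyond the scatter), smaller than the earlier one but in the same direction, because the earlier step of a 6.1-fold lower number from compound 1 to compound 2 (0.78 log units; beyond the scatter) lay beyond the scatter and the place of the change is the same. Compound 4 is therefore estimated at 180 nM, with a likely range from 60 nM to 500 nM.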

Compound 4, half-maximal inhibitory concentration: 405 nM
For compound 4 the middle estimate is 2.3-fold (0.35 log units) below the measured one; measured number inside the range.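

In this assay, for the compounds shown here, phenyl to 4-methylphenyl on the core of compound 3 gives a 1.3-fold lower number from compound 3 to compound 4 (0.11 log units; within the scatter) and no step that can be told from repeat measurement. The change therefore did not carry over in size from the core of compound 1 to the core of compound 3: the same change on two cores in this assay, a 6.1-fold lower number (0.78 log units; beyond the scatter) from compound 1 to compound 2 and a 1.3-fold lower number (0.11 log units; within the scatter) from compound 3 to compound 4, 4.7-fold (0.67 log units) apart, beyond the scatter of two such steps. With one pair on each core, this shows that the step depends on the core here, but not which difference between the two cores accounts for the gap, nor how the change behaves on any further core.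

The compounds shown leave open whether another group in the same place, such as an ethyl group, a methoxy group or an amine, would give a clear step on the core of compound 3. They also leave open whether such a group would keep the same size of step on both cores.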